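Replacing azetidin-1-yl on the shared core

The compounds below may be only part of what the source reports. "The series", "measured", "known", "first", "only" and "open" are said of these compounds alone.

Compound 1 `Cc1ccc2c(NCc3ccc(NC(=O)C4CCN(Cc5ccccc5)CC4)cc3)nc(N3CCC3)nc2c1` was tested in a functional assay on SV5A8 cells (Homo sapiens) for cytotoxicity; a lower number here means a stronger inhibitor, a higher number a weaker inhibitor. In this assay compound 1 gives only a limit, > 8500 nM, so its strength is not known as a number. Two related compounds stand at limits as well. Compound 2 `Cc1ccc2c(NCc3ccc(NC(=O)C4CCN(Cc5cccc(F)c5)CC4)cc3)nc(N(C)C)nc2c1` gives the limit > 4170 nM. Compound 3 `CCCCN1CCC(C(=O)Nc2ccc(CNc3nc(N(C)C)nc4cc(C)ccc34)cc2)CC1` gives the limit > 10500 nM. The step that the two limits leave unreadable from compound 2 to compound 3 therefore cannot be read, because the limit of > 4170 nM in this assay, at which 1 of the 3 values shown sits, and the limit of > 10500 nM in this assay, at which 1 of the 3 values shown sits, are both limits rather than numbers. Compound 4 `Cc1ccc2c(NCc3ccc(NC(=O)C4CCN(Cc5ccccc5)CC4)cc3)nc(N(C)CCN(C)C)nc2c1` differs from compound 1 by (2-(dimethylamino)ethyl)(methyl)amino in place of azetidin-1-yl on an aromatic carbon. Going by the values given here, no measured step touches this position, and the single measured step is itself unreadable, so neither a direction nor a size for the change can be drawn from the measured compounds. All three shown values, including (the limit of > 8500 nM in this assay, at which 1 of the 3 values shown sits), are limits, which leaves weak activity as the common picture across the set, with no compound standing apart. Compound 4 is therefore expected to give a value near 9000 nM, between 3000 nM and 30000 nM, most likely again reported only as a limit. The expected step that the limit leaves unreadable from compound 1 to compound 4 is an estimate only and does not point beyond the scatter.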

Compound 4, half-maximal inhibitory concentration: > 8830 nM
Compound 4 was reported as a limit (the forecaster's own chance of this, stated with the estimate: 80%); the middle value is on the limit's open side.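

Going by these compounds alone, compound 1 and compound 4 are both reported only as limits in this assay, so no step between them can be read. The compounds shown leave open how strongly any of them acts in this assay, and whether this replacement on the shared core changes that strength at all.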